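Isopropyl in place of ethyl at the limit

The compounds below may be only part of what the source reports. "The series", "measured", "known", "first", "only" and "open" are said of these compounds alone.

Values in a functional assay on cells (Platelet, Homo sapiens) for inhibition (a higher number here means a weaker inhibitor, a lower number a stronger inhibitor), follow, each one a limit.
- Compound 1 `CCOC(=O)c1ccc(-c2nn(Cc3cccc(F)c3)c3ccccc23)cc1` gives > 10000 nM as a limit.
- Compound 2 `CCOC(=O)c1ccc(-c2nn(Cc3ccc(OC)cc3)c3ccccc23)cc1` gives > 10000 nM as a limit.
- Compound 3 `CCOC(=O)c1ccc(-c2nn(CC)c3ccccc23)cc1` gives > 10000 nM as a limit.

Compound 3 stands at > 10000 nM in this assay as a limit and not as a number. The whole series sits at the limit of > 10000 nM in this assay, at which 3 of the 3 values shown sit, and so offers no ranking.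

Compound 4 `CCOC(=O)c1ccc(-c2nn(C(C)C)c3ccccc23)cc1` carries methyl in place of hydrogen on a saturated chain carbon bound to an aromatic nitrogen and a saturated chain carbon, which is ethyl to isopropyl, with the count methyl in place of hydrogen on a saturated chain carbon bound to an aromatic nitrogen and a saturated chain carbon as the difference from compound 3.

Two measured steps change the group on that same carbon, namely a step that the two limits leave unreadable from compound 1 to compound 3 and a step that the two limits leave unreadable from compound 2 to compound 3 and neither has a readable size. They support no expected direction. The expected change is a step that the limit leaves unreadable from compound 3 to compound 4 and it is no more than an estimate from these limits. Compound 4 is expected to remain at the limit of the assay, most likely reported only as a limit. For compound 4 the estimated value is 15000 nM with an estimated range from 6000 nM to 40000 nM in this reading.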

Compound 4, half-maximal inhibitory concentration: > 10000 nM
Compound 4 gave a limit, no number; the forecaster's own chance of this, stated with the estimate: 85%; the middle value lies beyond the limit too.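

For the compounds shown here, compound 4 also gives only a limit, so no step from compound 1, compound 2 or compound 3 to compound 4 can be read, and the series stays unranked: the limit of > 10000 nM in this assay, at which 4 of the 4 values shown sit. The compounds shown leave open whether any group on the aromatic nitrogen separates them in this assay.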